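From a benzyl thioether to a chlorophenyl ketone

A few compounds are considered here, and "the series" means these few. Any claim that something is new, unique, unknown or untested is made for them only; others in the source may bear on it.

Of the compounds shown here, two sharing one core have been tested in a functional assay on PC-3M cells (Homo sapiens) for cytotoxicity, read by MTT assay, with a stated time of 48 h; on this read-out higher numbers stand for weaker inhibition and lower numbers for stronger inhibition. Compound 1 `CCc1nnc(SCC(=O)c2ccc(Cl)cc2)n1N1C(=O)c2ccccc2C1=O` carries an ethyl group and a ((4-chlorophenyl)carbonyl)methyl group on the sulfur. In this assay compound 1 gives > 200000 nM, which is a limit of the assay rather than a number. Compound 2 `CCCc1nnc(SCc2ccccc2)n1N1C(=O)c2ccccc2C1=O` carries a propyl group and a benzyl group on the sulfur. In this assay compound 2 gives > 200000 nM, again a limit of the assay. Compound 2 therefore stands at the same limit as compound 1, and nothing separates the two on the numbers shown; the limit of > 200000 nM in this assay, at which 2 of the 2 values shown sit, is the whole of the evidence. Compound 3 `CCCc1nnc(SCC(=O)c2ccc(Cl)cc2)n1N1C(=O)c2ccccc2C1=O` differs from compound 2 by (4-chlorophenyl)carbonyl in place of phenyl on a saturated chain carbon bound to a sulfur. With both neighbours sitting at the limit, the step is expected to be a number no higher from compound 2 to compound 3 (the limit leaves the size open), not beyond the scatter. Compound 3 is expected to give 200000 nM, within 60000 nM to 500000 nM.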

Compound 3, half-maximal inhibitory concentration: > 200000 nM
Compound 3: a limit, no number; the forecaster's own chance of this, stated with the estimate: 85%; the middle value sits exactly at the limit.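

Compound 3 also gives only a limit of the assay, so neither its step from compound 2 nor its step from compound 1 can be read: the limit of > 200000 nM in this assay, at which 3 of the 3 values shown sit.

The compounds shown leave open whether (4-chlorophenyl)carbonyl in place of phenyl, or the propyl and ethyl difference, changes anything in this assay.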